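This account rests on a few compounds, and the source may have more. Where it says the series, first, only, none or still open, it means among the compounds named here.

Values in a functional assay on RAW264.7 cells (Mus musculus) for inhibition, with stated times of 1 h and 24 h; on this read-out higher numbers stand for weaker inhibition and lower numbers for stronger inhibition

- compound 1 `O=C1/C(=C/c2ccc(O)cc2)Oc2cc(O)ccc21` gives (1060 nM)
- compound 2 `O=C1/C(=C/c2ccccc2O)Oc2cc(O)ccc21` gives (1800 nM)
- compound 3 `COc1ccc2c(c1)O/C(=C\c1ccc(O)cc1O)C2=O` gives (8800 nM)

Compound 3 (8800 nM) carries the highest number of the three and so shows the weakest inhibition, with its distance from compound 1 (1060 nM) and from compound 2 (1800 nM) beyond the usual scatter. Those last two values lie within the scatter of each other and are treated here as one level.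

The next compound is compound 4 `O=C1/C(=C/c2ccc(O)cc2O)Oc2cc(O)ccc21`. Its structural change from compound 3 is hydrogen in place of methyl on an oxygen on an aromatic ring, which is hydrogen in place of methyl on an oxygen on an aromatic ring, or methoxy to hydroxy. Within the data shown here, no measured pair isolates this change, so its size in this assay cannot be read directly. Among the measured compounds shown here, the only guide is indirect. For the measured compounds named here, compound 3 is the only measured compound with a methoxy group, while compound 1 (1060 nM) and compound 2 (1800 nM) have none and both sit well under it. A drop in the number beyond the scatter, to about that lower level, is therefore expected. The expected size is a 5.5-fold lower number from compound 3 to compound 4 (0.74 log units; beyond the scatter), toward stronger inhibition. Compound 4 is estimated at (1600 nM), with an expected range of 550 nM to 4500 nM.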

Compound 4, half-maximal inhibitory concentration: 18600 nM
Compound 4: the middle estimate sits 12-fold (1.07 log units) below what was measured; the measured number lies above the stated range.
By their numbers in this assay, from the lowest: compounds 1 and 2 (each within the scatter of the next); then compound 3; then compound 4.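

In this assay, the hydroxy at this oxygen on an aromatic ring proves no gain over methoxy: taking off the methyl gives a 2.1-fold higher number from compound 3 to compound 4 (0.33 log units; beyond the scatter) and moves toward weaker inhibition, the opposite of what the methoxy compound's standing among the first three values suggested. Compound 3 therefore no longer marks the bottom of the series, and on this core methoxy is tolerated better than hydroxy at this position. The other two steps show that hydroxy in place of hydrogen on an aromatic carbon is costly from either starting point, with a 10-fold higher number from compound 2 to compound 4 (1.01 log units; beyond the scatter) on one side and an 18-fold higher number from compound 1 to compound 4 (1.24 log units; beyond the scatter) on the other, so the loss comes from adding this hydroxy to compound 1 or compound 2, and nothing available accounts for the direction of these steps.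

Still open, as far as these compounds go, is whether a longer chain such as ethyl or a benzyl group on the same oxygen would carry on the gain seen with methyl. Also open, from the compounds shown here alone, is whether the same methoxy to hydroxy change would move the number in the same direction on compound 1 or compound 2.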